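Swapping an Aromatic Acid for a Saturated Amide

The compounds below may be only part of what the source reports. "The series", "measured", "known", "first", "only" and "open" are said of these compounds alone.

Three compounds share one core and differ only in the group on an amine nitrogen in a ring. Compound 1 `O=C(c1ccc(Cl)cc1)N1CCC(NS(=O)(=O)c2cc(S(=O)(=O)c3ccccc3)ccc2C(F)(F)F)CC1` gives 1800 nM in an assay on U2OS cells for inhibition of secreted frizzled-related protein 1 (Homo sapiens), read by a luciferase reporter, with a stated time of 18 h; a lower number here means that less compound is needed, a higher number that more compound is needed for the effect. Compound 2 `N#Cc1cccc(S(=O)(=O)N2CCC(NS(=O)(=O)c3cc(S(=O)(=O)c4ccccc4)ccc3C(F)(F)F)CC2)c1` gives 170 nM. Compound 3 `O=C(O)c1ccc(N2CCC(NS(=O)(=O)c3cc(S(=O)(=O)c4ccccc4)ccc3C(F)(F)F)CC2)cc1` gives 230 nM. Compound 3 stands second highest of these three numbers: its nearest neighbour is compound 2, separated by a 1.4-fold higher number from compound 2 to compound 3 (0.13 log units; within the scatter), and its furthest is compound 1, separated by a 7.8-fold lower number from compound 1 to compound 3 (0.89 log units; beyond the scatter).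

Compound 4 `O=C([C@H]1CCNC1)N1CCC(NS(=O)(=O)c2cc(S(=O)(=O)c3ccccc3)ccc2C(F)(F)F)CC1` is not yet measured. It differs from compound 3 by (pyrrolidin-3-yl)carbonyl in place of 4-carboxyphenyl on an amine nitrogen in a ring. For the measured compounds named here, two measured steps bear on this change. a 7.8-fold lower number from compound 1 to compound 3 (0.89 log units; beyond the scatter) shows that replacing (4-chlorophenyl)carbonyl with 4-carboxyphenyl lowered the number markedly, and an 11-fold lower number from compound 1 to compound 2 (1.02 log units; beyond the scatter) shows a still larger fall for (3-cyanophenyl)sulfonyl. Going by the values given here, compound 4 returns to a carbonyl on the ring nitrogen, but carries a five-membered non-aromatic ring in place of any aromatic ring, a pattern no measured compound shows. A step back toward a higher number is therefore expected, though the size is uncertain. Compound 4 is estimated at 900 nM, between 250 nM and 3500 nM. The expected step is a 3.9-fold higher number from compound 3 to compound 4 (0.59 log units; beyond the scatter).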

Compound 4, half-maximal effective concentration: 700 nM
For compound 4 the middle estimate is 1.3-fold (0.11 log units) above the measured one, and the stated range covers the measured number.
By their numbers in this assay, from the lowest: compounds 2 and 3 (each within the scatter of the next); then compound 4; then compound 1.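

In this assay, for the compounds shown here, the new result puts a non-aromatic ring at this position for the first time, and the number rises, with a 3.0-fold higher number from compound 3 to compound 4 (0.48 log units; beyond the scatter) and a 4.1-fold higher number from compound 2 to compound 4 (0.61 log units; beyond the scatter) marking the distance from the two lowest compounds. The same group also shows that the carbonyl link does not fix the outcome on its own: with the carbonyl kept, pyrrolidin-3-yl in place of 4-chlorophenyl on the carbonyl carbon gives a 2.6-fold lower number from compound 1 to compound 4 (0.41 log units; beyond the scatter) and so moves the number down. Among these four compounds, the two with a carbonyl on the ring nitrogen, compound 1 and compound 4, both stand higher than compound 2 and compound 3, and none goes against this, though four compounds are a small basis for a pattern.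

No measurement at hand explains why any of these steps occurs. As far as these compounds go, it also stays open whether the carbonyl link or the loss of the aromatic ring accounts for the rise in compound 4, a question that a pyrrolidin-3-yl on a sulfonyl or a 4-carboxyphenyl on a carbonyl would help to separate, and the other stereo form of the pyrrolidine is equally unknown.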